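This account rests on a few compounds, and the source may have more. Where it says the series, first, only, none or still open, it means among the compounds named here.

In a toxicity assay on mitochondria from liver (Rattus norvegicus) for inhibition, in the presence of a further agent that is not named here (on this read-out lower numbers stand for stronger inhibition and higher numbers for weaker inhibition), compound 1 `N#Cc1cc(C(=O)N2CCc3ccccc32)cc(Cl)c1O` gives 31000 nM and compound 2 `O=C(c1cc(Cl)c(O)c(C(F)(F)F)c1)N1CS(=O)(=O)c2ccccc21` gives 18000 nM, so these two values lie within the scatter of each other. Compound 3 `CSc1cc(C(=O)N2CS(=O)(=O)c3ccccc32)cc(Cl)c1O` differs from compound 2 in one place: it has methylsulfanyl in place of trifluoromethyl on an aromatic carbon, ortho to a hydroxy group (methylsulfanyl in place of trifluoromethyl on an aromatic carbon). Among the compounds with values here, no measured pair yet shows what this exchange does. The expected step of a 1.1-fold higher number from compound 2 to compound 3 (0.05 log units; within the scatter) therefore stays within the scatter, with no firm direction. For compound 3 the estimated value is 20000 nM, with an expected range of 8000 nM to 50000 nM.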

Compound 3, half-maximal inhibitory concentration: 59000 nM
The estimate for compound 3 lay 3.0-fold (0.47 log units) below the measured number, and the stated range ends below it.
By their numbers in this assay, from the lowest: compounds 2, 1 and 3 (each within the scatter of the next, the first and the last beyond it).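

In this assay, within the data shown here, putting methylsulfanyl in place of trifluoromethyl on the aromatic carbon ortho to a hydroxy group gives a 3.3-fold higher number from compound 2 to compound 3 (0.52 log units; beyond the scatter) and so shows, as the earlier compounds could not, that this position responds to the group it carries. The higher number here means weaker inhibition, though the step is modest. No measurement shown accounts for this change.

On these data alone, this is one exchange on one core, so it remains open whether the step would carry over to the core of compound 1. As far as these compounds go, how an amine or a carboxylic acid at this position would read also remains open.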